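This account rests on a few compounds, and the source may have more. Where it says the series, first, only, none or still open, it means among the compounds named here.

Working notes on the series. Compound 1 `CC[n+]1ccc(CCC(=O)c2cc3cc(OC)c(OC)cc3s2)cc1` gives 25000 ug/mL in a physicochemical assay for solubility; a higher number here means a more soluble compound, a lower number a less soluble compound. For the measured compounds named here, compound 2 `C=CC[n+]1ccc(CCC(=O)c2cc3cc(OC)c(OC)cc3s2)cc1` gives 25000 ug/mL in this assay; the step of no change at the digits printed from compound 1 to compound 2 (within the scatter) is flat, so compound 2 sits level with compound 1 on the only measured pair. Compound 3 `CCC[n+]1ccc(CCC(=O)c2cc3cc(OC)c(OC)cc3s2)cc1` differs from compound 2 by ethyl in place of vinyl on a saturated chain carbon bound to an aromatic nitrogen. Going by the values given here, the one step that bears on this, no change at the digits printed from compound 1 to compound 2 (within the scatter), showed nothing beyond the scatter for a change at the same place, so the expected step of no change at the digits printed from compound 2 to compound 3 (within the scatter) is none beyond the scatter. Compound 3 is therefore expected at 25000 ug/mL, within 12000 ug/mL to 50000 ug/mL.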

Compound 3, solubility: 16000 ug/mL
Compound 3: middle estimate off by 1.6-fold (0.19 log units), on the high side; the range from low to high includes it.
By their numbers in this assay, from the lowest: compounds 3, 1 and 2 (each within the scatter of the next).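

In this assay the change to ethyl from vinyl gives a 1.6-fold lower number from compound 2 to compound 3 (0.19 log units; within the scatter) at this place, on a saturated chain carbon bound to an aromatic nitrogen, so removing the double bond outside aromatic rings moves the read-out by nothing beyond the scatter. Methyl in place of hydrogen, two bonds along the chain from an aromatic nitrogen, gives a 1.6-fold lower number from compound 1 to compound 3 (0.19 log units; within the scatter) as well, so the one added chain carbon also stays inside the scatter. No evidence on the reason for these readings is available. Open, on these data alone, is whether a longer chain, a benzyl group or a carboxylic acid at this place would move the number beyond the scatter.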